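Two Methyls on the Outer Ring: What to Expect

The source may report more compounds than this note shows. Statements on the series, on what has been measured and on what is new or still open speak of the compounds shown alone.

Measured in a functional assay on DLD-1 cells (Homo sapiens) for antiproliferative activity, read by CellTiter-Glo, with a stated time of 72 h; on this read-out higher numbers stand for weaker inhibition and lower numbers for stronger inhibition:
Compound 1, `COc1ccccc1-c1cccc(S(=O)(=O)N2CCC(N3CCC(C)CC3)CC2)c1`, gives 21 nM.
Compound 2, `CC1CCN(C2CCN(S(=O)(=O)c3cccc(-c4ccccc4F)c3)CC2)CC1`, gives 10 nM.
Compound 3, `CC1CCN(C2CCN(S(=O)(=O)c3cccc(-c4ccccc4C(F)(F)F)c3)CC2)CC1`, gives 10 nM.

Compound 3 sits level with compound 2 at the bottom of these three numbers, with no change at the digits printed from compound 2 to compound 3 (within the scatter), while a 2.1-fold lower number from compound 1 to compound 3 (0.32 log units; beyond the scatter). Compound 4, `Cc1cc(C)cc(-c2cccc(S(=O)(=O)N3CCC(N4CCC(C)CC4)CC3)c2)c1`, differs from compound 3 by 3,5-dimethylphenyl in place of 2-(trifluoromethyl)phenyl on an aromatic carbon. For the measured compounds named here, no measured step changes this ring in the same way; the steps that touch it are a 2.1-fold lower number from compound 1 to compound 2 (0.32 log units; beyond the scatter) and a 2.1-fold lower number from compound 1 to compound 3 (0.32 log units; beyond the scatter), both modest, and no change at the digits printed from compound 2 to compound 3 (within the scatter). Changes on this ring have so far moved the number little, so compound 4 is expected to stay near compound 3, with a 1.5-fold higher number from compound 3 to compound 4 (0.18 log units; within the scatter), estimated at 15 nM (range 5 nM to 50 nM).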

Compound 4, half-maximal inhibitory concentration: 41 nM
Estimate against measurement, compound 4: 2.7-fold (0.44 log units) below; measured number inside the range.
By their numbers in this assay, from the lowest: compounds 2 and 3 (each within the scatter of the next); then compounds 1 and 4 (each within the scatter of the next).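

For the compounds shown here, this position is less forgiving than the earlier compounds suggested: 3,5-dimethylphenyl raises the number against 2-(trifluoromethyl)phenyl (a 4.1-fold higher number from compound 3 to compound 4 (0.61 log units; beyond the scatter)) and against 2-fluorophenyl (a 4.1-fold higher number from compound 2 to compound 4 (0.61 log units; beyond the scatter)), and these are the largest steps seen so far on this ring. Against 2-methoxyphenyl, the same group gives no separable difference (a 2.0-fold higher number from compound 1 to compound 4 (0.29 log units; within the scatter)). Nothing measured here explains the rise in the number.

The change alters both the groups and where they sit on the ring, and these two effects cannot be separated here. On these data alone, whether a single methyl, or an amine, would keep the number near that of compound 3 remains open.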